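A few compounds are considered here, and "the series" means these few. Any claim that something is new, unique, unknown or untested is made for them only; others in the source may bear on it.

Measured compounds in an ADME assay on BJ cells (Homo sapiens) for antiproliferative activity, with a stated time of 72 h; a higher number here means that more compound is needed for the effect, a lower number that less compound is needed:

Compound 1, `COc1ccc(-c2cc(=O)c3c(OC)cc(OC)cc3[nH]2)cc1`: compound 1 gives > 62000 nM, which is a limit of the assay.
Compound 2, `COc1ccc(-c2cc(=O)c3c(OC)cc(OC)cc3n2S(=O)(=O)c2ccc(C#N)cc2)cc1`: compound 2 gives > 17200 nM, again only a limit.
Compound 3, `COc1ccc(-c2cc(=O)c3c(OC)cc(OC)cc3n2S(=O)(=O)c2c(F)c(F)c(F)c(F)c2F)cc1`: compound 3 gives > 34400 nM, again only a limit.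

Compound 3 therefore stands at a limit in this assay, and the two other values shown are limits as well: one sits at the limit of > 17200 nM in this assay, at which 1 of the 3 values shown sits, one at the limit of > 34400 nM in this assay, at which 1 of the 3 values shown sits, one at the limit of > 62000 nM in this assay, at which 1 of the 3 values shown sits. Neither measured step can be read: a step that the two limits leave unreadable from compound 1 to compound 2 and a step that the two limits leave unreadable from compound 2 to compound 3 are both left open by the limits on either side.

Compound 4, `COc1ccc(-c2cc(=O)c3c(OC)cc(OC)cc3n2S(=O)(=O)c2ccc(Br)cc2)cc1`, differs from compound 3 only at the sulfonyl sulfur: 4-bromophenyl in place of 2,3,4,5,6-pentafluorophenyl on a sulfonyl sulfur. Both steps that bear on this position are unreadable, so no direction and no size can be taken from them, and nothing among the three compounds points to a readable change beyond the scatter.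

Compound 4 is accordingly expected to give about 50000 nM, within a range of 15000 nM to 200000 nM, most probably again as a limit. The expected step is a step that the limit leaves unreadable from compound 3 to compound 4.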

Compound 4, half-maximal effective concentration: > 86200 nM
Compound 4 was reported as a limit (the forecaster's own chance of this, stated with the estimate: 85%); middle value at least 1.7-fold (0.23 log units) away from the limit.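

Compound 4 joins compound 1, compound 2 and compound 3 as a limit in this assay, so its steps from each of these three compounds cannot be read. The compounds shown leave open how far any of these sulfonyl groups shifts the antiproliferative concentration.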